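Series notes: aryl swap on the carbonyl, compound 2 to compound 3

This account rests on a few compounds, and the source may have more. Where it says the series, first, only, none or still open, it means among the compounds named here.

Measured in a functional assay on MDA-MB-468 cells (Homo sapiens) for cytotoxicity, read by sulforhodamine B assay, with a stated time of 48 h, tested at 100 uM; on this read-out lower numbers stand for a stronger effect and higher numbers for a weaker effect at the one concentration tested:
compound 1 `COc1ccc(-c2cc(/C=C/C(=O)c3ccc(N)cc3)[nH]n2)cc1`: -51%
compound 2 `COc1cc(-c2cc(/C=C/C(=O)c3ccc(N)cc3)[nH]n2)cc(OC)c1OC`: -65%

Compound 2 stands lowest of the two numbers in this assay; its nearest neighbour is compound 1, whose number lies higher by a margin beyond the scatter. Among the compounds with values here, no pair differing in a single place has been measured, so no step size is known. Compound 3 `COc1cc(-c2cc(/C=C/C(=O)c3ccc(Cl)c(Cl)c3)[nH]n2)cc(OC)c1OC` is not yet measured; it differs from compound 2 by 3,4-dichlorophenyl in place of 4-aminophenyl on a carbonyl carbon. Within the data shown here, with no comparable step available, the expected change in this assay is a modest weakening, possibly within the scatter: a number 10 percentage points higher from compound 2 to compound 3 (within the scatter). On that basis compound 3 is estimated at -55%, range -85% to -20%.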

Compound 3, a percentage reported as activity, at one concentration (the size of the read-out at that concentration, not a potency): -37%
Beside the measured number, compound 3's estimate is 18 percentage points below it; the measured number falls inside the stated range.
By their numbers in this assay, from the lowest: compound 2; then compound 1; then compound 3.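

The aryl group on a carbonyl carbon gives the series its first readable step: in this assay, 3,4-dichlorophenyl in place of 4-aminophenyl gives a number 28 percentage points higher from compound 2 to compound 3 (beyond the scatter). This position therefore responds to the swap, yet the number stays negative without the amine. Nothing measured accounts for the shift.

On these data alone, the swap removes the amine and adds both chlorines in one step, so the share of each stays open. A 4-chlorophenyl or 4-hydroxyphenyl group at this place would separate them, and whether the swap acts alike on the core of compound 1 is also unresolved.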